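A few compounds are considered here, and "the series" means these few. Any claim that something is new, unique, unknown or untested is made for them only; others in the source may bear on it.

In a functional assay on HCT-116 cells (Homo sapiens) for inhibition, read by sulforhodamine B assay, with a stated time of 72 h (a higher number here means a weaker inhibitor, a lower number a stronger inhibitor), three compounds have been measured:

compound 1 `Cc1ccc(C2=Nn3c(nnc3C(C)c3ccc(CC(C)C)cc3)SC2)cc1` gives 4000 nM
compound 2 `CC(c1ccc(-c2ccccc2)c(F)c1)c1nnc2n1N=C(c1ccc(Cl)cc1Cl)CS2` gives 6900 nM
compound 3 `COc1ccc2cc(C(C)c3n[nH]c(=S)n3N)ccc2c1` gives 20200 nM

Compound 2 holds the second highest of these three numbers. Compound 1 sits nearest to it, within the usual scatter, so the two cannot be told apart; compound 3 lies furthest, with a higher number beyond the scatter.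

Compound 4 `CC(c1ccc(-c2ccccc2)c(F)c1)c1nnc2n1N=C(c1ccc(Br)cc1)CS2` differs from compound 2 in one place: 4-bromophenyl in place of 2,4-dichlorophenyl on a carbon with a double bond to nitrogen. For the measured compounds named here, no measured pair shows the effect of such a change, so no step beyond the scatter is expected in either direction. The step from compound 2 to compound 4 is estimated at a 1.2-fold lower number from compound 2 to compound 4 (0.06 log units; within the scatter). Compound 4 is therefore expected to give about 6000 nM in this assay, with a likely range from 2500 nM to 15000 nM.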

Compound 4, half-maximal inhibitory concentration: 7100 nM
Compound 4: middle estimate off by 1.2-fold (0.07 log units), on the low side; the measured number falls inside the stated range.
By their numbers in this assay, from the lowest: compounds 1, 2 and 4 (each within the scatter of the next); then compound 3.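

The exchange of 2,4-dichlorophenyl for 4-bromophenyl gives the first step read at this position, a 1.0-fold higher number from compound 2 to compound 4 (0.01 log units; within the scatter) in this assay, so the two compounds cannot be told apart. With the rest of the molecule unchanged, these two halogen-bearing phenyl groups are thus interchangeable in this assay, at least for this pair. Nothing available bears on why this is so.

As far as these compounds go, whether an amine, a carboxylic acid or a pyridine ring in this place would move the number beyond the scatter remains open. So does whether the same exchange would read alike on the core of compound 1.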